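Fluorophenyl position swap in a sulfonyl quinoline series

A few compounds are considered here, and "the series" means these few. Any claim that something is new, unique, unknown or untested is made for them only; others in the source may bear on it.

Measured so far:
- compound 1, `O=S(=O)(c1cc(Cl)cc(Cl)c1)c1cnc2cc(F)ccc2c1-c1ccccc1F`: 0.93 mL/min
- compound 2, `COc1ccc(-c2c(S(=O)(=O)c3cc(Cl)cc(Cl)c3)cnc3c(F)cccc23)cc1`: 2.11 mL/min
- compound 3, `O=S(=O)(c1ccc(F)c(Cl)c1)c1cnc2c(F)cccc2c1-c1ccc(Cl)cc1`: 0.01 mL/min

Three compounds of the shared core have been run in an ADME assay on microsomes from liver (Homo sapiens) for metabolic stability, tested at 2.5 uM; a lower number here means slower removal, a higher number faster removal of the compound. Compound 1 gives 0.93 mL/min, the second highest of the three numbers. Compound 2 sits nearest to it with a higher number, and the gap between compound 1 and compound 2 is beyond the scatter. Compound 3 is furthest, with a much lower number, again beyond the scatter. Compound 2 and compound 3 differ from compound 1 in more than one place, so no single-change step can be read from them.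

Compound 4, `O=S(=O)(c1cc(Cl)cc(Cl)c1)c1cnc2cc(F)ccc2c1-c1ccc(F)cc1`, has not yet been measured in this assay. It differs from compound 1 by one change only: 4-fluorophenyl in place of 2-fluorophenyl on an aromatic carbon. The same atoms are present, joined differently.

Among the compounds with values here, no single-change step of this kind exists among the measured compounds, so the expectation rests on compound 1 alone. The step from compound 1 to compound 4 is expected to be small, a 1.2-fold higher number from compound 1 to compound 4 (0.07 log units; within the scatter), and likely not beyond the scatter. Compound 4 is therefore estimated at 1.1 mL/min, within a range of 0.4 mL/min to 3 mL/min.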

Compound 4, intrinsic clearance in a liver preparation (reported as CLH), per the amount of preparation that the assay uses: 0.18 mL/min
Estimate against measurement, compound 4: 6.1-fold (0.79 log units) above; the measured number lies below the stated range.
By their numbers in this assay, from the lowest: compound 3; then compound 4; then compound 1; then compound 2.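

In this assay, 4-fluorophenyl in place of 2-fluorophenyl gives a 5.2-fold lower number from compound 1 to compound 4 (0.71 log units; beyond the scatter), so moving one fluorine on this aromatic group, with the same atoms present, is enough to shift the number beyond the scatter. Within the data shown here, this is the first single-change step, and it shows that at this aromatic carbon, opposite the ring nitrogen, the placement of a substituent matters as well as its identity. Nothing measured here accounts for the difference.

Still open, going by these compounds, is whether the same swap gives a step of similar size and direction when other parts of the shared core differ. Also open, on these data alone, is how an unsubstituted phenyl, or a phenyl carrying an amine, would stand at this position against compound 1 and compound 4.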